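A Furan Ring Replaces Propyl at the Carbonyl Carbon

The source may hold more compounds than are shown below. What is called first, only, known or untested is meant among the compounds shown, and "the series" means these compounds.

Of the compounds shown here, three share the same bicyclic hydrazone fragment and have been tested in an ADME assay on Vero cells (Chlorocebus sabaeus) for cytotoxicity, read by spectrophotometry, with a stated time of 4 days; a higher number here means that more compound is tolerated, a lower number that less compound is tolerated. Compound 2, `CCCC(=O)N/N=C1\C[C@H]2CC[C@]1(C)C2(C)C`, gives 854000 nM in this assay. Compound 3, `CC12C=CC3(O1)C(C(=O)N1c4ccccc4SC13)C2C(=O)N/N=C1\C[C@H]2CC[C@]1(C)C2(C)C`, gives 67200 nM. Compound 1, `CC12C=CC3(O1)C(C(=O)N1CCSC13)C2C(=O)N/N=C1\C[C@H]2CC[C@]1(C)C2(C)C`, reports only a limit of the assay, > 250000 nM, and so stands at the limit of > 250000 nM in this assay, at which 1 of the 3 values shown sits. Among the two numbers that are not limits, compound 2 therefore sits highest, and its gap to compound 3 lies beyond the usual scatter of this assay.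

The unmeasured compound 4, `CC1(C)[C@@H]2CC[C@@]1(C)/C(=N/NC(=O)c1ccco1)C2`, differs from compound 2 in one place: furan-2-yl in place of propyl on a carbonyl carbon. Among the compounds with values here, nothing among the measured compounds reproduces this exchange, so no measured step can be quoted for it. Compound 2 itself is already tolerated at a high concentration, so the expected change is a small one, if any, and the estimate stays close to the value of compound 2 while allowing a modest drop. For compound 4 a step of a 1.7-fold lower number from compound 2 to compound 4 (0.23 log units; within the scatter) is expected in this assay. Compound 4 is thus estimated at 500000 nM, with a range from 150000 nM to 1500000 nM, a step that would not by itself stand out from the scatter.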

Compound 4, half-maximal cytotoxic concentration: 285000 nM
For compound 4 the middle estimate is 1.8-fold (0.24 log units) above the measured one; measured number inside the range.
By their numbers in this assay, from the lowest: compound 3; then compound 4; then compound 2.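

In this assay the series now holds a step that can be read in one place, furan-2-yl in place of propyl on a carbonyl carbon whose other neighbour is an amide-type nitrogen, and it reads a 3.0-fold lower number from compound 2 to compound 4 (0.48 log units; beyond the scatter). The earlier compounds shown here could not show this, as none of them differ in only one place; it now appears that the group on this carbonyl carbon can move the number in this assay by more than the usual scatter, although the step is modest and compound 4 still gives 285000 nM in a high range of concentrations. Nothing measured here bears on why the number falls with this exchange.

A single exchange cannot tell whether the furan-2-yl group matters as this particular ring or merely as something other than propyl, and a phenyl ring, a thiophen-2-yl ring or a longer chain on the same carbonyl carbon would help to separate those readings. Compound 1 and compound 3 differ from compound 4 in more than one place, so how the group at this position relates to theirs cannot be read from these values.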